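This account rests on a few compounds, and the source may have more. Where it says the series, first, only, none or still open, it means among the compounds named here.

Measured in a functional assay on HEK293 cells for agonist activity at D(4) dopamine receptor (Homo sapiens), read by FLIPR; a lower number here means that less compound is needed, a higher number that more compound is needed for the effect:
compound 1 `Cc1cc(NC(=O)CN2CCC(c3cccc[n+]3[O-])CC2)ccc1F` gives 18 nM
compound 2 `O=C(CN1CCC(c2cccc[n+]2[O-])CC1)Nc1cc(Cl)cc(Cl)c1` gives 160 nM
compound 3 `Cc1cc(Br)ccc1NC(=O)CN1CCC(c2cccc[n+]2[O-])CC1` gives 66 nM

Compound 3 holds the middle of these three numbers; its distances to the other two are a 2.4-fold lower number from compound 2 to compound 3 (0.38 log units; beyond the scatter) and a 3.7-fold higher number from compound 1 to compound 3 (0.56 log units; beyond the scatter), both modest and beyond the scatter. Compound 4 `O=C(CN1CCC(c2cccc[n+]2[O-])CC1)Nc1ccccc1F` differs from compound 3 by 2-fluorophenyl in place of 4-bromo-2-methylphenyl on an amide-type nitrogen. Within the data shown here, no measured step removes both bromine and methyl; the nearest precedents are a 3.7-fold higher number from compound 1 to compound 3 (0.56 log units; beyond the scatter) and an 8.9-fold higher number from compound 1 to compound 2 (0.95 log units; beyond the scatter), which show that rearranging halogen and methyl on this ring shifts this assay by modest amounts only. A small step is therefore expected, a 1.5-fold lower number from compound 3 to compound 4 (0.17 log units; within the scatter), leaning toward a lower number because the fluorine-bearing compound 1 gives 18 nM. Compound 4 is estimated at 45 nM, range 15 nM to 150 nM.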

Compound 4, half-maximal effective concentration: 270 nM
Compound 4: the middle estimate sits 6.0-fold (0.78 log units) below what was measured; measured number outside the range, above it.
By their numbers in this assay, from the lowest: compound 1; then compound 3; then compounds 2 and 4 (each within the scatter of the next).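

In this assay, among these compounds, 2-fluorophenyl on the amide-type nitrogen gives a 4.1-fold higher number from compound 3 to compound 4 (0.61 log units; beyond the scatter) and a 15-fold higher number from compound 1 to compound 4 (1.18 log units; beyond the scatter), so the aryl group at this place matters more than the earlier steps showed, and a fluorine on the ring does not by itself keep the number low. The step of a 1.7-fold higher number from compound 2 to compound 4 (0.23 log units; within the scatter) leaves compound 4 level with compound 2. Nothing at hand explains these differences.

Still open, as far as these compounds go, is how unsubstituted phenyl or 3-methylphenyl would compare on the same nitrogen, which would help separate the contributions of methyl and fluorine.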